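The source may report more compounds than this note shows. Statements on the series, on what has been measured and on what is new or still open speak of the compounds shown alone.

Measured compounds:
compound 1 `COc1cc(C2CC(c3cccc4ccccc34)=NN2C(C)=O)ccc1OCc1cn(Cc2ccc([N+](=O)[O-])cc2)nn1` — 79%
compound 2 `COc1ccc(C2CC(c3ccc(OCc4cn(Cc5ccc([N+](=O)[O-])cc5)nn4)cc3)=NN2C(C)=O)cc1` — 26%

In a functional assay on THP-1 cells (Homo sapiens) for inhibition, read by sulforhodamine B assay, tested at 100 uM (on this read-out lower numbers stand for less inhibition of growth and higher numbers for more inhibition of growth at the one concentration tested), compound 1 gives 79%. In this assay compound 2 gives 26%. Compound 1 stands highest of the two numbers; its nearest neighbour, compound 2, lies a long way lower, beyond the scatter. Among the compounds with values here, compound 1 and compound 2 differ in several places at once, so no single-change step between measured compounds is available, and their two values show only that compound 1 is the stronger inhibitor of growth of the pair.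

The compound still to be measured is compound 3 `COc1cc(C2CC(c3ccccc3)=NN2C(C)=O)ccc1OCc1cn(Cc2ccc([N+](=O)[O-])cc2)nn1`. It differs from compound 1 in one place: phenyl in place of naphthalen-1-yl on a carbon with a double bond to nitrogen. Within the data shown here, the only guide is that the one measured compound carrying a single six-membered aromatic ring on that carbon, compound 2, sits far below compound 1, though compound 2 also differs elsewhere. A moderate downward step in this assay is expected for this change, and compound 3 is estimated at 50%, range 25% to 75%. The expected step is a number 29 percentage points lower from compound 1 to compound 3 (beyond the scatter).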

Compound 3, percent growth inhibition at one concentration: 10%
Beside the measured number, compound 3's estimate is 40 percentage points above it; measured number below the stated range.
By their numbers in this assay, from the lowest: compound 3; then compound 2; then compound 1.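

In this assay, within the data shown here, the change of phenyl in place of naphthalen-1-yl on a carbon with a double bond to nitrogen gives a number 69 percentage points lower from compound 1 to compound 3 (beyond the scatter) with the rest of the structure of compound 1 held fixed, which is the first single-change reading. The earlier pair differed in several places, so it could not tie the gap in growth inhibition to any one site; this step shows that this position alone can carry a large change, and that the high value of compound 1 does not survive loss of one of the two six-membered aromatic rings of naphthalen-1-yl. No data at hand account for the size of this step.

On these data alone, the series offers only these two groups at this carbon, so it remains unknown whether the count of aromatic rings or some other feature of naphthalen-1-yl tracks the value. Cyclohexyl, or phenyl bearing an amine or a carboxylic acid, would test this, and the reading at one concentration leaves the shape of any dose response open.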